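Swapping Chloro for Methyl on a Weak Transporter Inhibitor

The source may hold more compounds than are shown below. What is called first, only, known or untested is meant among the compounds shown, and "the series" means these compounds.

In a functional assay on brain for inhibition of Norepinephrine transporter (Rattus norvegicus) (on this read-out lower numbers stand for stronger inhibition and higher numbers for weaker inhibition), three compounds have been measured:
compound 1, `CN(C)C/C=C(/c1ccc(Cl)cc1)c1cccnc1`, gives 10000 nM;
compound 2, `CCNC/C=C(/c1ccc(Br)cc1)c1cccnc1`, gives 26000 nM;
compound 3, `CN(C)C/C=C(/c1ccc(C(F)(F)F)cc1)c1cccnc1`, gives 13000 nM.

Compound 1 stands at the lowest of these three numbers. Its nearest neighbour is compound 3, and the step of a 1.3-fold higher number from compound 1 to compound 3 (0.11 log units; within the scatter) lies within the scatter. Among the measured compounds shown here, compound 2 is the furthest, and its value is beyond the scatter from that of compound 1, but compound 2 differs in two places, so no single step connects them.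

Compound 4, `Cc1ccc(/C(=C/CN(C)C)c2cccnc2)cc1`, has not yet been measured. It differs from compound 1 as follows: methyl in place of chloro on an aromatic carbon. For the measured compounds named here, the only measured step at the same place, a 1.3-fold higher number from compound 1 to compound 3 (0.11 log units; within the scatter), shows that exchanging one small group for another on that aromatic carbon changed nothing beyond the scatter. On that basis compound 4 is expected to sit close to compound 1, with a step of a 1.2-fold higher number from compound 1 to compound 4 (0.08 log units; within the scatter) that is not expected to exceed the scatter. Compound 4 is therefore estimated at 12000 nM, within a range of 5000 nM to 30000 nM.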

Compound 4, half-maximal inhibitory concentration: > 29000 nM
Compound 4: a limit, no number; the forecaster's own chance of this, stated with the estimate: 20%; middle value at least 2.4-fold (0.38 log units) from the limit.
By their numbers in this assay, from the lowest: compounds 1, 3 and 2 (each within the scatter of the next, the first and the last beyond it). At a limit, above all of these: compound 4.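

In this assay compound 4 gives > 29000 nM, which is a limit of the assay and not a number. Methyl in place of chloro on this aromatic carbon gives an at least 2.9-fold higher number from compound 1 to compound 4 (0.46 log units; beyond the scatter), and methyl in place of trifluoromethyl gives an at least 2.2-fold higher number from compound 3 to compound 4 (0.34 log units; beyond the scatter), so this position, where chloro and trifluoromethyl had stayed within the scatter of each other, does not treat every exchange alike. Both steps give only a minimum size, and their full size stays unknown: the limit of > 29000 nM in this assay, at which 1 of the 4 values shown sits.

As far as these compounds go, whether a methoxy group, a fluorine atom or an amine at this place would stay near compound 1 or reach the limit of compound 4 remains open. Also open, from the compounds shown here alone, is whether methyl would behave the same way on the core of compound 2, which carries bromo and an ethylamino group.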